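Triazole carboxamide series: cyclohexyl for methyl at the ring carbon

This account rests on a few compounds, and the source may have more. Where it says the series, first, only, none or still open, it means among the compounds named here.

Three compounds have numbers in a functional assay on CHO cells for antagonist activity at prostaglandin E2 receptor EP4 subtype (Homo sapiens), read by calcium flux, with a stated time of 15 min; a lower number here means a stronger inhibitor, a higher number a weaker inhibitor. Compound 1 `C[C@H](NC(=O)c1c(C(F)(F)F)nnn1CCOc1ccc(F)cc1)c1ccc(C(=O)O)cc1` gives 276 nM and compound 3 `C[C@H](NC(=O)c1c(-c2ccccc2)nnn1Cc1ccc(F)cc1)c1ccc(C(=O)O)cc1` gives 330 nM; the two sit within the usual scatter of each other. Compound 2 `Cc1nnn(Cc2ccc(C(F)(F)F)cc2)c1C(=O)N[C@@H](C)c1ccc(C(=O)O)cc1` gives only a limit, > 10000 nM, which is the limit of > 10000 nM in this assay, at which 1 of the 3 values shown sits. Compound 4 `C[C@H](NC(=O)c1c(C2CCCCC2)nnn1Cc1ccc(C(F)(F)F)cc1)c1ccc(C(=O)O)cc1` is not yet measured; it differs from compound 2 by cyclohexyl in place of methyl on an aromatic carbon. Within the data shown here, no measured pair isolates that change. Compound 4 is expected to move from the limit of compound 2 to a measurable value, a step estimated as an at least 16-fold lower number from compound 2 to compound 4 (1.22 log units; beyond the scatter), since the numbered compounds 1 and 3 both carry a larger group on that ring carbon. For compound 4 the expected value in this assay is 600 nM, with a range from 120 nM to 5000 nM.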

Compound 4, half-maximal inhibitory concentration: 161 nM
For compound 4 the middle estimate is 3.7-fold (0.57 log units) above the measured one; the measured number falls inside the stated range.
By their numbers in this assay, from the lowest: compounds 4, 1 and 3 (each within the scatter of the next, the first and the last beyond it). At a limit, above all of these: compound 2.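

In this assay, among these compounds, cyclohexyl in place of methyl on an aromatic carbon gives the first pair that isolates a change at this position: an at least 62-fold lower number from compound 2 to compound 4 (1.79 log units; beyond the scatter). With all else held fixed, this ring carbon carries cyclohexyl and gives a measurable value, which methyl there does not. Compound 2 stands at a limit and not at a number, so the true size of the step stays unknown: the limit of > 10000 nM in this assay, at which 1 of the 4 values shown sits.

As far as these compounds go, whether an open chain such as isopropyl, or an amine, at this ring carbon would also give a measurable value stays open. So does whether the same change carries over to a compound with the ring nitrogen group of compound 1.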